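From Amine to Hydroxyamine in a Lipoxygenase Inhibitor Series

The source may hold more compounds than are shown below. What is called first, only, known or untested is meant among the compounds shown, and "the series" means these compounds.

Compound 1 `CCCCC/C=C\C/C=C\C/C=C\C=C\C(CCCC(=O)O)CC(=O)NO`: 190 nM
Compound 2 `CCCCC/C=C\C/C=C\C/C=C\C=C\C(N)CCCC(=O)O`: 25000 nM

In an assay for inhibition of Polyunsaturated fatty acid 5-lipoxygenase (Rattus norvegicus) (a higher number here means a weaker inhibitor, a lower number a stronger inhibitor), compound 2 holds the higher of the two numbers, and thus the weaker inhibition, separated from compound 1 by a 130-fold higher number from compound 1 to compound 2 (2.12 log units; beyond the scatter). Compound 3 `CCCCC/C=C\C/C=C\C/C=C\C=C\C(CCCC(=O)O)NO` has not yet been measured in this assay. It differs from compound 2 by hydroxy in place of hydrogen on an amine nitrogen. Going by the values given here, only one measured step bears on this change: the step from compound 1 to compound 2, which was large and removed from the chain a group that carried a hydroxy on nitrogen. Compound 3 restores a hydroxy on nitrogen, though not the whole of the group lost in that step. The number for compound 3 in this assay is therefore expected to move downward, by an estimated 17-fold lower number from compound 2 to compound 3 (1.22 log units; beyond the scatter). Compound 3 is estimated at 1500 nM, with a range from 200 nM to 10000 nM.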

Compound 3, half-maximal inhibitory concentration: 21000 nM
Compound 3: middle estimate off by 14-fold (1.15 log units), on the low side, outside the stated range (above it).
By their numbers in this assay, from the lowest: compound 1; then compounds 3 and 2 (each within the scatter of the next).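

In this assay, going by these compounds alone, hydroxy in place of hydrogen on an amine nitrogen gives no step that can be told from the scatter (a 1.2-fold lower number from compound 2 to compound 3 (0.08 log units; within the scatter)). A hydroxy on nitrogen at this position is thus not enough on its own to reach the level of compound 1, as the one-place comparison with the (hydroxycarbamoyl)methyl group shows (a 110-fold higher number from compound 1 to compound 3 (2.04 log units; beyond the scatter)). What separates compound 1 from compound 3 therefore lies in the rest of that group, its carbonyl and its methylene link, and nothing measured here says why.

The compounds shown leave open whether the carbonyl or the methylene link carries the difference. A primary amide or a carboxylic acid in place of the hydroxycarbamoyl group, or a longer chain between that group and the saturated chain carbon, would bear on this.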